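The source may report more compounds than this note shows. Statements on the series, on what has been measured and on what is new or still open speak of the compounds shown alone.

Working notes on the series. Compound 1 `CN1CCN(c2ccc(Nc3ncc(F)c(NC4CCCC4)n3)cc2)CC1` and compound 2 `CN1CCC(NC(=O)c2ccc(Nc3ncc(Br)c(NC4CCCC4)n3)cc2)CC1` share a core and are read in a functional assay on HCT-8 cells (Homo sapiens) for cytotoxicity, read by MTT assay, with a stated time of 48 h; on this read-out higher numbers stand for weaker inhibition and lower numbers for stronger inhibition. In this assay compound 1 gives 29000 nM, while compound 2 gives 3600 nM, the lower of the two numbers and a gap beyond the scatter; the two differ in more than one place, so the values are only set side by side. Compound 3 `CN1CCC(NC(=O)c2ccc(Nc3ncc(F)c(NC4CCCC4)n3)cc2)CC1` follows from compound 2 by fluoro in place of bromo on an aromatic carbon. Compound 1 also carries fluoro and is the weaker of the measured pair, so a step upward beyond the scatter is expected, a 2.5-fold higher number from compound 2 to compound 3 (0.40 log units; beyond the scatter). Compound 3 is estimated at 9000 nM, within 3000 nM to 27000 nM.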

Compound 3, half-maximal inhibitory concentration: 16000 nM
Estimate against measurement, compound 3: 1.8-fold (0.25 log units) below; the range from low to high includes it.
By their numbers in this assay, from the lowest: compound 2; then compounds 3 and 1 (each within the scatter of the next).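

Within the data shown here, at this aromatic carbon, ortho to a cyclopentylamino group, the halogen alone separates two compounds for the first time: in this assay, fluoro in place of bromo gives a step beyond the scatter (a 4.4-fold higher number from compound 2 to compound 3 (0.65 log units; beyond the scatter)) in the direction of weaker inhibition. With fluoro held fixed, (1-methylpiperidin-4-yl)carbamoyl in place of 4-methylpiperazin-1-yl stays within the scatter (a 1.8-fold lower number from compound 1 to compound 3 (0.26 log units; within the scatter)) in this assay. No measured evidence bears on the reason for either result.

Going by these compounds, what chloro or an amine on this aromatic carbon would give remains open, as does whether bromo keeps its edge over fluoro alongside 4-methylpiperazin-1-yl.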